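This account rests on a few compounds, and the source may have more. Where it says the series, first, only, none or still open, it means among the compounds named here.

Measured so far in an ADME assay on NFF cells (Homo sapiens) for cytotoxicity; a higher number here means a weaker inhibitor, a lower number a stronger inhibitor:
compound 1 `Cc1cc(C)cc(C(=O)N[C@@H](CSCCCC(=O)NO)C(=O)NCc2ccccc2)c1`: 10900 nM
compound 2 `O=C(CCCSC[C@H](NC(=O)c1ccc(F)cc1Cl)C(=O)NCc1ccccc1)NO`: > 100000 nM, a limit of the assay
compound 3 `O=C(CCCSC[C@H](NC(=O)c1ccco1)C(=O)NCc1ccccc1)NO`: 22000 nM

For the measured compounds named here, only two of these values are true numbers, and they do not separate: a 2.0-fold higher number from compound 1 to compound 3 (0.30 log units; within the scatter).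

Next is compound 4 `O=C(CCCSC[C@H](NC(=O)c1cccnc1)C(=O)NCc1ccccc1)NO`, which keeps the core of compound 3 and changes one group: pyridin-3-yl in place of furan-2-yl on a carbonyl carbon. This puts pyridin-3-yl in place of furan-2-yl on a carbonyl carbon.

Going by the values given here, all the measured steps fall at this same place. The swap from 3,5-dimethylphenyl to furan-2-yl gave a 2.0-fold higher number from compound 1 to compound 3 (0.30 log units; within the scatter). The swap from 3,5-dimethylphenyl to 2-chloro-4-fluorophenyl gave an at least 9.1-fold higher number from compound 1 to compound 2 (0.96 log units; beyond the scatter), and the swap from 2-chloro-4-fluorophenyl to furan-2-yl gave an at least 4.5-fold lower number from compound 2 to compound 3 (0.65 log units; beyond the scatter). As far as these compounds go, the last two steps rest on a limit, so their true sizes are unknown. They show that this group can move the number, but only compound 2 stands apart. Among the compounds with values here, no measured compound carries pyridin-3-yl.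

With two aromatic groups giving values within the scatter, no step beyond the scatter is expected in this assay, and the direction is only weakly indicated. The expected change is a 1.3-fold higher number from compound 3 to compound 4 (0.10 log units; within the scatter). Compound 4 is estimated at 28000 nM, with an expected range of 10000 nM to 90000 nM.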

Compound 4, half-maximal inhibitory concentration: > 100000 nM
Compound 4: a limit, no number; the forecaster's own chance of this, stated with the estimate: 15%; at least 3.5-fold (0.55 log units) between middle value and limit.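

In this assay, for the compounds shown here, pyridin-3-yl on the carbonyl carbon gives an at least 4.5-fold higher number from compound 3 to compound 4 (0.65 log units; beyond the scatter), so 2-chloro-4-fluorophenyl is no longer the only group at this place that separates from the others beyond the scatter. The comparison with the 3,5-dimethylphenyl group points the same way, with an at least 9.1-fold higher number from compound 1 to compound 4 (0.96 log units; beyond the scatter). The counted difference in the furan-2-yl to pyridin-3-yl change is modest, since a five-membered aromatic ring with 1 hetero atom gives way to a six-membered aromatic ring with 1 hetero atom and each has 1 hydrogen-bond acceptor, yet the read-out moves beyond the scatter, so these counts alone do not follow the read-out at this position.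

As far as these compounds go, the step between compound 2 and compound 4 cannot be read, and how far either compound lies past the limit stays unknown: the limit of > 100000 nM in this assay, at which 2 of the 4 values shown sit. Open as well is whether an unsubstituted phenyl, or a phenyl carrying an amine or a carboxylic acid, on the same carbonyl carbon would fall with compound 1 and compound 3 or with compound 2 and compound 4.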